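Compound 4 and its configurational relatives in jejunum

The source may report more compounds than this note shows. Statements on the series, on what has been measured and on what is new or still open speak of the compounds shown alone.

The series is followed in an ADME assay on Jejunum (Mus musculus, strain C57BL/6) for metabolic stability, read by HPLC, with a stated time of 12 h; a lower number here means that the compound disappears faster, a higher number that the compound lasts longer. Compound 1 `O=C(O)[C@H](CO)NC(=O)[C@H]1C[C@H](O)CN1` gives > 12 h, which is a limit of the assay and not a number. Compound 2 `O=C(N[C@H](CO)C(=O)O)[C@@H]1C[C@H](O)CN1` gives > 12 h, again a limit. Compound 3 `O=C(O)[C@H](CO)NC(=O)[C@H]1C[C@@H](O)CN1` gives > 12 h, also a limit and not a number, so it has no readable rank in the series. Compound 4 `O=C(N[C@H](CO)C(=O)O)[C@@H]1C[C@@H](O)CN1` has not yet been measured.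

The structural change is the two compounds have the same atoms and bonds and differ only in configuration as drawn: 2 of 3 stereo elements differ; a stereocentre at a saturated chain carbon is drawn S in compound 3 and R in compound 4; a stereocentre at a saturated ring carbon is drawn R in compound 3 and S in compound 4. Nothing leaves and nothing enters: the saturated chain carbon goes from S to R and a saturated ring carbon from R to S.

The closest measured precedent is a step that the two limits leave unreadable from compound 1 to compound 2, which also turns a saturated chain carbon from S to R and a saturated ring carbon from R to S. The other two are a step that the two limits leave unreadable from compound 1 to compound 3 and a step that the two limits leave unreadable from compound 2 to compound 3. None of the three provides a size to carry over. Even so, the limit of > 12 h in this assay, at which 3 of the 3 values shown sit, holds across three different configurations, so no step beyond the scatter and no direction is expected in this assay. The estimated outcome is a step that the limit leaves unreadable from compound 3 to compound 4. For compound 4 the estimated half-life is 15 h, with an expected range from 10 h to 30 h, and a report as a limit is the likeliest form of the result.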

Compound 4, half-life: 0.33 h
For compound 4 the middle estimate is 45-fold (1.66 log units) above the measured one; the whole stated range lies above it.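

In this assay, inverting one saturated ring carbon alone gives an at least 36-fold lower number from compound 2 to compound 4 (1.56 log units; beyond the scatter), and nothing else separates the pair: the fact that compounds 2 and 4 differ only in the configuration as drawn

The other two configurations give the same reading, with an at least 36-fold lower number from compound 3 to compound 4 (1.56 log units; beyond the scatter) on inverting a saturated chain carbon and a saturated ring carbon, and an at least 36-fold lower number from compound 1 to compound 4 (1.56 log units; beyond the scatter) on inverting all stereocentres. The half-lives of compounds 1, 2 and 3 are all limits, so the steps among those three cannot be read, but compound 4 now shows that the long half-life does not hold for every configuration of the shared core.

As far as these compounds go, the true size of each of the three new steps stays open, as only a lower bound on the gap can be read. Also open, from the compounds shown here alone, is whether the short half-life of compound 4 belongs to this configuration alone or persists when an amine replaces the hydroxyl, or when an ester replaces the carboxylic acid.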